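Swapping Chloro for Methoxy on the Aryl Ring

This account rests on a few compounds, and the source may have more. Where it says the series, first, only, none or still open, it means among the compounds named here.

Three compounds share one core. Compound 1 `CCCN(c1nc(-c2ccc(Cl)cc2OC)n(C)n1)C(CC)c1ccc(C(F)(F)F)cc1` gives 12 nM in an in vitro assay on Ltk- cells for binding affinity to corticotropin-releasing factor receptor 1 (Homo sapiens); on this read-out higher numbers stand for weaker inhibition and lower numbers for stronger inhibition; compound 2 `CCCN(CC1CC1)c1nc(-c2ccc(Cl)cc2OC)n(C)n1` gives 2600 nM; compound 3 `CCCN(CCC)c1nc(-c2ccc(Cl)cc2Cl)n(C)n1` gives 3400 nM. Compound 3 sits within the scatter of compound 2 but far from compound 1, whose number is much lower. Compound 4 `CCCN(CCC)c1nc(-c2ccc(Cl)cc2OC)n(C)n1` has not been measured yet; it differs from compound 3 by methoxy in place of chloro on an aromatic carbon, so it carries the same aryl group as compound 2 and the same dipropylamino group as compound 3. Within the data shown here, since no measured pair isolates this change, the step from compound 3 to compound 4 is expected to stay within the scatter, a 1.4-fold lower number from compound 3 to compound 4 (0.13 log units; within the scatter), because compound 2 with the same aryl group already gives 2600 nM. Compound 4 is therefore estimated at 2500 nM, likely between 700 nM and 8000 nM.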

Compound 4, inhibition constant: > 10000 nM
Compound 4 was reported as a limit; the forecaster's own chance of this, stated with the estimate: 5%; middle value at least 4.0-fold (0.60 log units) from the limit.
By their numbers in this assay, from the lowest: compound 1; then compounds 2 and 3 (each within the scatter of the next). At a limit, above all of these: compound 4.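

Compound 4 is reported only as a limit, not a number: the limit of > 10000 nM in this assay, at which 1 of the 4 values shown sits. Methoxy in place of chloro on this aromatic carbon does not hold the binding of the dipropylamino compound, giving an at least 2.9-fold higher number from compound 3 to compound 4 (0.46 log units; beyond the scatter). Ethyl in place of cyclopropyl gives an at least 3.8-fold higher number from compound 2 to compound 4 (0.58 log units; beyond the scatter), and hydrogen in place of 4-(trifluoromethyl)phenyl gives a large step, an at least 830-fold higher number from compound 1 to compound 4 (2.92 log units; beyond the scatter), so the aryl change is not the only one that counts.

On these data alone, with a limit, the true size of all three steps stays open. As far as these compounds go, whether a fluoro or methyl group on this aromatic carbon would fare better than methoxy also stays open.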